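Cytotoxicity notes: methoxy removal on the fused core

The source may hold more compounds than are shown below. What is called first, only, known or untested is meant among the compounds shown, and "the series" means these compounds.

Measured so far:
- compound 1 `COc1ccc2nc(C)cc(OCC(=O)Nc3cc(C)cc(C)c3)c2n1`: > 100000 nM
- compound 2 `COc1ccc2c(c1)c(=O)ccn2CC(=O)Nc1cc(C)cc(C)c1`: > 100000 nM
- compound 3 `Cc1cc(C)cc(NC(=O)COc2ccnc3ccccc23)c1`: > 100000 nM

In an ADME assay on HepG2 cells (Homo sapiens) for cytotoxicity, with a stated time of 48 h (on this read-out higher numbers stand for weaker inhibition and lower numbers for stronger inhibition), compound 1 returns only a limit, > 100000 nM, not a number. In this assay compound 2 likewise returns only a limit, > 100000 nM. Compound 3 also sits at a limit in this assay, > 100000 nM. So compound 2 stands where every other measured compound stands: at the limit of > 100000 nM in this assay, at which 3 of the 3 values shown sit. Within the data shown here, no two measured compounds differ in a single place, so no step between measured values can be read off, and the three limits give no ranking among them.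

Compound 4 `Cc1cc(C)cc(NC(=O)Cn2ccc(=O)c3ccccc32)c1` is the next compound, not yet tested in this assay. It differs from compound 2 in one place: hydrogen in place of methoxy on an aromatic carbon. The methoxy leaves and hydrogen enters on an aromatic carbon of the fused core.

Because the measured compounds all sit at the limit of > 100000 nM in this assay, at which 3 of the 3 values shown sit, no step beyond the scatter is expected in this assay; the step from compound 2 to compound 4 is estimated as a step that the limit leaves unreadable from compound 2 to compound 4. Compound 4 is expected to come out at about 150000 nM, within 60000 nM to 400000 nM, most likely reported again as a limit.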

Compound 4, half-maximal inhibitory concentration in the HepG2 assay: 63100 nM
Beside the measured number, compound 4's estimate is 2.4-fold (0.38 log units) above it; the range from low to high includes it.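

In the HepG2 assay, hydrogen in place of methoxy on this aromatic carbon gives an at least 1.5-fold lower number from compound 2 to compound 4 (0.19 log units; that floor lies within the scatter); this is only a floor, yet the series now holds its first number rather than a limit. In a physicochemical assay for permeability, using PAMPA (a higher number here means that the compound crosses the layer faster, a lower number that the compound crosses the layer more slowly), compound 2 gives 190 nm/s and compound 4 gives 450 nm/s, which is a 2.4-fold higher number from compound 2 to compound 4 (0.37 log units; beyond the scatter), so the same change also moves this second read-out beyond the scatter. Within the HepG2 assay, compound 4 alone has left the limit shared by the others: the limit of > 100000 nM in the HepG2 assay, at which 3 of the 4 values shown sit.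

The true size of the step in the HepG2 assay cannot be read from a limit. From the compounds shown here alone, whether an amine, a carboxylic acid or a fluorine on this aromatic carbon would shift either read-out in the same direction stays open.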